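Trimethoxyphenyl Replaces Styryl on the Pyrazoline Core

The source may hold more compounds than are shown below. What is called first, only, known or untested is meant among the compounds shown, and "the series" means these compounds.

Measured compounds:
compound 1, `Cc1cc(O)c(C2=NN(c3ccc(S(N)(=O)=O)cc3)C(c3ccccc3Cl)C2)cc1Cl`, 3920 nM
compound 2, `Cc1cc(O)c(C2=NN(c3ccc(S(N)(=O)=O)cc3)C(/C=C/c3ccccc3)C2)cc1Cl`, 24000 nM

Both compounds were tested in a functional assay on MDA-MB-435 cells (Homo sapiens) for antiproliferative activity, with a stated time of 48 h; a higher number here means a weaker inhibitor of growth, a lower number a stronger inhibitor of growth. Compound 1 gives 3920 nM, and compound 2 gives 24000 nM, the higher of the two numbers, so compound 2 is the weaker growth inhibitor here. Among the measured compounds shown here, the one step measured so far, a 6.1-fold higher number from compound 1 to compound 2 (0.79 log units; beyond the scatter), shows that swapping a 2-chlorophenyl group for a 2-phenylethenyl group on the saturated ring carbon weakened growth inhibition well beyond the scatter.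

Compound 3, `COc1ccc(C2CC(c3cc(Cl)c(C)cc3O)=NN2c2ccc(S(N)(=O)=O)cc2)c(OC)c1OC`, has not yet been measured. It differs from compound 2 in one place: 2,3,4-trimethoxyphenyl in place of 2-phenylethenyl on a saturated ring carbon. This step returns an aromatic ring directly to the saturated ring carbon, as in compound 1, but the ring now carries three methoxy groups rather than a chlorine. For the measured compounds named here, the only step that bears on it is the reverse of the one just described: going from an aryl to a styryl group raised the number, so undoing that is expected to lower it again, though the new aryl group differs from that of compound 1 and no measured step tells how much that matters. Compound 3 is therefore estimated at 6000 nM, in the range 1500 nM to 30000 nM, a step of a 4.0-fold lower number from compound 2 to compound 3 (0.60 log units; beyond the scatter).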

Compound 3, concentration for total growth inhibition: 8470 nM
Estimate against measurement, compound 3: 1.4-fold (0.15 log units) below, within the range that was stated.
By their numbers in this assay, from the lowest: compound 1; then compound 3; then compound 2.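

In this assay, putting an aromatic ring back on the saturated ring carbon in place of 2-phenylethenyl gives a 2.8-fold lower number from compound 2 to compound 3 (0.45 log units; beyond the scatter) and so extends what compound 1 first suggested: across these three compounds, both groups with a ring attached directly to that carbon give lower numbers than the group that holds its ring out on a two-carbon link with a double bond. The identity of the aromatic group also counts, though less clearly, as 2,3,4-trimethoxyphenyl in place of 2-chlorophenyl gives a 2.2-fold higher number from compound 1 to compound 3 (0.33 log units; beyond the scatter), a step only just beyond the usual scatter, so this position responds to what the ring carries as well as to how the ring is attached. Nothing available here accounts for this order of the three groups, so the numbers describe the trend without explaining it.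

As far as these compounds go, it remains open how an unsubstituted phenyl ring, or a ring carrying a single methoxy group, would compare with the two substituted rings, so the contribution of each methoxy group cannot be separated. Also open, from the compounds shown here alone, is how this position would respond to a saturated cyclohexyl ring, or to a phenyl ring bearing an amine or a carboxylic acid.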